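The source may report more compounds than this note shows. Statements on the series, on what has been measured and on what is new or still open speak of the compounds shown alone.

Measured so far:

- compound 1, `COc1ccc(/C=C/C(=O)NCc2ccc(OCc3nc(C)c(C)nc3C)c(OC)c2)cc1`: 5050 nM in a functional assay on SH-SY5Y cells (Homo sapiens) for cytotoxicity, read by MTT assay, with stated times of 24 h and 4 h; a lower number here means that less compound is needed, a higher number that more compound is needed for the effect
- compound 2, `COc1cc(CNC(=O)/C=C/c2cccc(OC)c2OC)ccc1O`: 5490 nM in this assay

Compound 2 and compound 1 give numbers in this assay that lie within the usual scatter of each other, so the two cannot be told apart on this read-out. Compound 1 already carries a (3,5,6-trimethylpyrazin-2-yl)methyl ether, though on a different core, and in this assay compound 1 gives 5050 nM, which is no different in practice from the free phenol of compound 2.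

Compound 3, `COc1cc(CNC(=O)/C=C/c2cccc(OC)c2OC)ccc1OCc1nc(C)c(C)nc1C`, has not been measured yet in this assay. It differs from compound 2 by (3,5,6-trimethylpyrazin-2-yl)methyl in place of hydrogen on an oxygen on an aromatic ring. Going by the values given here, no step between measured compounds shows what this change does on the core of compound 2. Among the compounds with values here, the only guide is that compound 1, which carries the same group, is indistinguishable from compound 2, so no step beyond the scatter is expected in either direction. For compound 3 in this assay the expected number is 5200 nM, within a range of 2000 nM to 13000 nM, which means an expected step of a 1.1-fold lower number from compound 2 to compound 3 (0.02 log units; within the scatter).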

Compound 3, half-maximal effective concentration: 7150 nM
Beside the measured number, compound 3's estimate is 1.4-fold (0.14 log units) below it, and the stated range covers the measured number.
By their numbers in this assay, from the lowest: compounds 1, 2 and 3 (each within the scatter of the next).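

Going by these compounds alone, the pair that differs only at this position gives the first direct reading of it. In this assay, (3,5,6-trimethylpyrazin-2-yl)methyl in place of hydrogen on an oxygen on an aromatic ring gives (a 1.3-fold higher number from compound 2 to compound 3 (0.11 log units; within the scatter)), so adding this whole ring to the free hydroxy leaves a number that repeated measurements could not separate from the original. With that ether kept, 2,3-dimethoxyphenyl in place of 4-methoxyphenyl on the double-bonded chain carbon gives (a 1.4-fold higher number from compound 1 to compound 3 (0.15 log units; within the scatter)), so neither single change shown produces a step that stands out from the scatter, and no measurement available here speaks to why.

The compounds shown place only a hydrogen and this one large group on that oxygen, so it stays open whether a chain ending in an amine or a carboxylic acid would give a step beyond the scatter. Since all three compounds lie within the scatter of one another, they also leave open which part of these molecules, if any, the number in this assay depends on.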